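The source may hold more compounds than are shown below. What is called first, only, known or untested is meant among the compounds shown, and "the series" means these compounds.

In an assay on isolated protein for inhibition of Polyunsaturated fatty acid 5-lipoxygenase (Homo sapiens), read by fluorescence, with a stated time of 10 min (a lower number here means a stronger inhibitor, a higher number a weaker inhibitor), three compounds have been measured so far, and none gave a number.

Compound 1 `O=C(Oc1cccc(Cl)c1Cl)c1cc([N+](=O)[O-])cc([N+](=O)[O-])c1` stops at the limit > 50000 nM.
Compound 2 `O=C(Oc1ccc(-c2ccccc2)cc1)c1cc([N+](=O)[O-])cc([N+](=O)[O-])c1` stops at the limit > 50000 nM.
Compound 3 `O=C(Nc1cccc(Br)c1)c1cc([N+](=O)[O-])cc([N+](=O)[O-])c1` stops at the limit > 50000 nM.

Compound 3 therefore stands nowhere in particular on these numbers: its value is a limit of this assay and not a measurement, and it shares that standing with both others, as the limit of > 50000 nM in this assay, at which 3 of the 3 values shown sit, shows. Going by the values given here, no step between two measured compounds can be drawn from such values, so nothing is known about how any single change moves the read-out here.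

Compound 4 `O=C(Nc1cccc(-c2ccccc2)c1)c1cc([N+](=O)[O-])cc([N+](=O)[O-])c1` has not been measured. It differs from compound 3 by phenyl in place of bromo on an aromatic carbon. Compound 2 also carries a phenyl on its aromatic ring and sits at the limit > 50000 nM. Among the compounds with values here, since no measured step exists, the expectation for the change from compound 3 to compound 4 in this assay is no movement beyond the scatter, and most likely again only a limit. Compound 4 is estimated at 50000 nM, with a range from 20000 nM to 200000 nM. That estimate corresponds to an expected step of a number no higher from compound 3 to compound 4 (the limit leaves the size open).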

Compound 4, half-maximal inhibitory concentration: 30 nM
Compound 4: middle estimate off by 1700-fold (3.22 log units), on the high side, and the stated range ends above it.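

Going by these compounds alone, with phenyl in place of bromo on an aromatic carbon, meta to a large group, this assay shows an at least 1600-fold lower number from compound 3 to compound 4 (3.22 log units; beyond the scatter), the first step that can be read, and it shows that the read-out depends strongly on what this position carries. Compound 4 is also the only compound shown that gives a number rather than a limit, so the series now has one measured point to work from: the limit of > 50000 nM in this assay, at which 3 of the 4 values shown sit. The value of compound 3 is a limit, so the true size of this step remains open, and nothing shown explains why the change has so large an effect.

The compounds shown leave open whether an aromatic ring is needed at this position or whether another group with more atoms than bromo, such as a cyclohexyl or a longer alkyl chain, would serve as well. They also leave open whether the amide linkage is required alongside the phenyl, and whether the phenyl itself would still give such a value if it carried an amine or a carboxylic acid.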